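Working notes: extending the chain to compound 3

A few compounds are considered here, and "the series" means these few. Any claim that something is new, unique, unknown or untested is made for them only; others in the source may bear on it.

- Compound 1 `COc1ccc(N(C)c2nc(C)nc3ccccc23)cc1OCC[Se]C#N`: 18 nM
- Compound 2 `COc1ccc(N(C)c2nc(C)nc3ccccc23)cc1OCCCC[Se]C#N`: 512 nM
- Compound 3 `COc1ccc(N(C)c2nc(C)nc3ccccc23)cc1OCCCCC[Se]C#N`: not yet measured

In a functional assay on HCT-116 cells (Homo sapiens) for inhibition, read by MTT assay, with a stated time of 48 h (on this read-out higher numbers stand for weaker inhibition and lower numbers for stronger inhibition), compound 2 gives 512 nM, the higher of the two numbers and so the weaker inhibition. Compound 1 gives 18 nM. The next change is a group of 4 heavy atoms (2 carbon, 1 nitrogen, 1 selenium; no ring) in place of a group of 3 heavy atoms (1 carbon, 1 nitrogen, 1 selenium; no ring), on a saturated chain carbon, four bonds along the chain from an oxygen on an aromatic ring. The shared core stays untouched, and only the chain carrying the selenium and nitrile grows.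

For the measured compounds named here, only one measured step bears on this: a 28-fold higher number from compound 1 to compound 2 (1.45 log units; beyond the scatter). That step is large and beyond the scatter, and it also extends the same chain, though by a larger group change than the one now in view. Two compounds establish no trend, and nothing yet shows whether the numbers keep rising with chain length. A further rise in this assay is expected because a 28-fold higher number from compound 1 to compound 2 (1.45 log units; beyond the scatter) went in that direction, but a smaller one, with wide uncertainty. The expected step is a 1.8-fold higher number from compound 2 to compound 3 (0.24 log units; within the scatter). Compound 3 is estimated at 900 nM, with an expected range of 250 nM to 3500 nM.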

Compound 3, half-maximal inhibitory concentration: 256 nM
Compound 3: middle estimate off by 3.5-fold (0.55 log units), on the high side; measured number inside the range.
By their numbers in this assay, from the lowest: compound 1; then compounds 3 and 2 (each within the scatter of the next).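

In this assay, the result is a 2.0-fold lower number from compound 2 to compound 3 (0.30 log units; within the scatter), so adding to the chain at this place, on a saturated chain carbon, four bonds along the chain from an oxygen on an aromatic ring, does not separate these two compounds, and the large change seen on the first extension does not continue as a steady climb with chain length across the three compounds. The shortest chain of the series remains clearly apart, with a 14-fold higher number from compound 1 to compound 3 (1.15 log units; beyond the scatter), so compound 1 is now separated beyond the scatter from both longer-chain compounds, and the sensitivity to chain length appears confined to the step away from its chain. Nothing available on these compounds explains this pattern.

Going by these compounds, it remains open whether a longer chain than that of compound 3 would stay within the scatter of compound 3 or move away from it, and whether a chain shorter than that of compound 1 would keep the low number of the series. Also open, on these data alone, is whether the value of compound 1, 18 nM, would hold with a sulfur atom in place of the selenium, or with an amine in place of the selenium and nitrile together.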